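A few compounds are considered here, and "the series" means these few. Any claim that something is new, unique, unknown or untested is made for them only; others in the source may bear on it.

Working notes on the series. Among the compounds with values here, compound 1 `CCCSc1nnc(COc2ccccc2C2=NOC(c3ccc(Cl)cc3Cl)C2)n1NC(=O)c1ccccc1` is the only member with a number in an ADME assay (MDM cells, Homo sapiens) for cytotoxicity, read by resazurin assay, with a stated time of 3 days; on this read-out higher numbers stand for weaker inhibition and lower numbers for stronger inhibition; in this assay compound 1 gives 14.8 ug/mL. In this assay compound 2 `C=CCSc1nnc(COc2ccccc2C2=NOC(c3ccc(Cl)cc3Cl)C2)n1NC(=O)c1ccccc1` has "not determined" (no result reported), so its standing cannot be placed on the scale at all. Compound 3 `CCSc1nnc(COc2ccccc2C2=NOC(c3ccc(Cl)cc3Cl)C2)n1NC(=O)c1ccccc1` is the next member to be run in this assay. The change from compound 2 to compound 3 is methyl in place of vinyl on a saturated chain carbon bound to a sulfur. Within the data shown here, with no measured step between the compounds, no direction can be argued for the change, and nothing beyond the usual scatter is anticipated. Compound 3 is expected to come in at about 15 ug/mL, within a range of 6 ug/mL to 40 ug/mL.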

Compound 3, half-maximal inhibitory concentration: 1.8 ug/mL
Estimate against measurement, compound 3: 8.3-fold (0.92 log units) above; the whole stated range lies above it.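

In this assay, the group on sulfur proves sensitive to a small change: hydrogen in place of methyl on a saturated chain carbon, two bonds along the chain from a sulfur, gives an 8.2-fold lower number from compound 1 to compound 3 (0.91 log units; beyond the scatter). The change from vinyl to methyl cannot be read, as compound 2 has no result. No measurement available here accounts for the lower number of compound 3.

Open, as far as these compounds go, is whether a methyl or a butyl chain on the sulfur would extend this step or break it, and how an amine at the end of the chain would read.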